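The source may report more compounds than this note shows. Statements on the series, on what has been measured and on what is new or still open speak of the compounds shown alone.

Series notes on the shared core. Compound 1 `O=c1c(-c2ccc(O)cc2)coc2cc(OCCCCCCCCCO)ccc12` is the reference point; in an assay (Cricetulus griseus) for inhibition of aldehyde dehydrogenase, mitochondrial (Homo sapiens) (on this read-out lower numbers stand for stronger inhibition and higher numbers for weaker inhibition), compound 1 gives 700 nM. Compound 2 `O=C(O)COc1ccc2c(=O)c(-c3ccc(O)cc3)coc2c1` carries carboxy in place of 8-hydroxyoctyl on a saturated chain carbon bound to an oxygen on an aromatic ring; in this assay compound 2 gives 1200 nM. The step of a 1.7-fold higher number from compound 1 to compound 2 (0.23 log units; within the scatter) lies within the scatter, so compound 1 and compound 2 cannot be set apart on the numbers shown, and compound 1 stands as one of two values that are indistinguishable.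

Compound 3 `O=C(O)CCCCCCCCCOc1ccc2c(=O)c(-c3ccc(O)cc3)coc2c1` is not yet measured. Its change from compound 1 is carboxy in place of hydroxy on a saturated chain carbon, nine bonds along the chain from an oxygen on an aromatic ring. The chain is kept and only its terminal group is exchanged. For the measured compounds named here, the one measured step that bears on this is a 1.7-fold higher number from compound 1 to compound 2 (0.23 log units; within the scatter), where carboxy replaced the entire 8-hydroxyoctyl group and the number still moved within the scatter. Since a much larger change left the value within the scatter, no step beyond the scatter is expected here in this assay. The expected step is a 1.1-fold higher number from compound 1 to compound 3 (0.06 log units; within the scatter). Compound 3 is therefore estimated to give 800 nM in this assay, with a range of 350 nM to 1800 nM.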

Compound 3, half-maximal inhibitory concentration: 50 nM
Compound 3: middle estimate off by 16-fold (1.20 log units), on the high side; measured number outside the range, below it.
By their numbers in this assay, from the lowest: compound 3; then compounds 1 and 2 (each within the scatter of the next).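

In this assay, the end of the long chain proves to be a sensitive place: carboxy in place of hydroxy on a saturated chain carbon, nine bonds along the chain from an oxygen on an aromatic ring, gives a 14-fold lower number from compound 1 to compound 3 (1.15 log units; beyond the scatter) and so separates the two compounds clearly. The earlier step, a 1.7-fold higher number from compound 1 to compound 2 (0.23 log units; within the scatter), exchanged the whole 8-hydroxyoctyl group for carboxy and did not separate its two compounds, so carboxy on the short chain shows nothing of this size: compound 2 gives 1200 nM and compound 3, with carboxy at the end of the long chain, gives 50 nM in the same read-out. Across these three compounds, the low number appears only where carboxy and the long chain occur together, and nothing available on the series accounts for the step.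

Still open, on these data alone, is whether a carboxylic acid is required at the chain end, or whether an amide, a methyl ester or a tetrazole in the same place would give a similar number. Also open, as far as these compounds go, is how the number runs with chain length, both for carboxy chains of intermediate length and for a longer chain.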